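Swapping the indole amide for a cyclopropane amide

The source may hold more compounds than are shown below. What is called first, only, known or untested is meant among the compounds shown, and "the series" means these compounds.

In an assay on membranes from striatum (strain Sprague-Dawley) for displacement of a labelled ligand from sodium-dependent dopamine transporter (Rattus norvegicus), read by scintillation counting, with a stated time of 120 min (on this read-out lower numbers stand for stronger inhibition and higher numbers for weaker inhibition), three compounds have been measured:
compound 1 `Fc1ccc(C(SCCNC2CCN(Cc3ccc(Cl)cc3)CC2)c2ccc(F)cc2)cc1` gives 39.6 nM
compound 2 `Fc1ccc(C(SCCNC2CCN(Cc3ccc(C(F)(F)F)cc3)CC2)c2ccc(F)cc2)cc1` gives 190 nM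
compound 3 `O=C(c1cc2ccccc2[nH]1)N1CCC(NCCSC(c2ccc(F)cc2)c2ccc(F)cc2)CC1` gives 177 nM

Compound 3 holds the second highest number of the three; compound 2 lies within the scatter of it, as a 1.1-fold lower number from compound 2 to compound 3 (0.03 log units; within the scatter) shows, while compound 1 lies clearly lower. Compound 4 `O=C(C1CC1)N1CCC(NCCSC(c2ccc(F)cc2)c2ccc(F)cc2)CC1` differs from compound 3 in one place: cyclopropyl in place of 1H-indol-2-yl on a carbonyl carbon. For the measured compounds named here, only the steps at this ring nitrogen bear on the change, namely a 4.5-fold higher number from compound 1 to compound 3 (0.65 log units; beyond the scatter) and a 1.1-fold lower number from compound 2 to compound 3 (0.03 log units; within the scatter); both end at compound 3, and neither tests a group as small as cyclopropyl. Compound 4 is expected to show a modest upward step, a 2.3-fold higher number from compound 3 to compound 4 (0.35 log units; beyond the scatter), with an estimated value of 400 nM in this assay, ranging from 120 nM to 1500 nM.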

Compound 4, inhibition constant: 178 nM
Compound 4: the middle estimate sits 2.2-fold (0.35 log units) above what was measured; the range from low to high includes it.
By their numbers in this assay, from the lowest: compound 1; then compounds 3, 4 and 2 (each within the scatter of the next).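

Cyclopropyl and 1H-indol-2-yl cannot be told apart on the carbonyl carbon (a 1.0-fold higher number from compound 3 to compound 4 (0.00 log units; within the scatter)), so the aromatic rings and hydrogen-bond donor of the larger group are not needed to hold this level. The cyclopropylcarbonyl group also matches 4-(trifluoromethyl)benzyl on the ring nitrogen (a 1.1-fold lower number from compound 2 to compound 4 (0.03 log units; within the scatter)), whereas 4-chlorobenzyl remains clearly stronger (a 4.5-fold higher number from compound 1 to compound 4 (0.65 log units; beyond the scatter)). No measured evidence is available to explain these results. Still open, on these data alone, is whether a methyl or aminomethyl group on the same carbonyl carbon would hold this level.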